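The compounds below may be only part of what the source reports. "The series", "measured", "known", "first", "only" and "open" are said of these compounds alone.

Series values in a functional assay for inhibition, with Homo sapiens as the target; a higher number here means a weaker inhibitor, a lower number a stronger inhibitor:
- compound 1 `CSC(Cc1cccc(OCC(=O)O)c1)c1nc(-c2ccccc2)c(-c2ccccc2)o1`: 1300 nM
- compound 2 `CC(C)C(Cc1cccc(OCC(=O)O)c1)c1nc(-c2ccccc2)c(-c2ccccc2)o1`: 970 nM

Compound 2, at 970 nM, cannot be separated from compound 1, and the two values lie within the scatter of each other. Next in line is compound 3 `O=C(O)COc1cccc(CC(CCO)c2nc(-c3ccccc3)c(-c3ccccc3)o2)c1`, which carries 2-hydroxyethyl in place of isopropyl on a saturated chain carbon bound to an aromatic carbon and a saturated chain carbon.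

Going by the values given here, only one measured step bears on this place, a 1.3-fold lower number from compound 1 to compound 2 (0.13 log units; within the scatter), and it lies within the scatter. Among the compounds with values here, that step shows this assay tolerating an exchange of methylsulfanyl for isopropyl, but no measured compound has 2-hydroxyethyl here, so the evidence for this change is thin. A large move in either direction has no support in the data, and a modest shift toward a higher number is the working expectation, held with wide margins. The expected change is a 1.9-fold higher number from compound 2 to compound 3 (0.27 log units; within the scatter). Compound 3 is estimated at 1800 nM, with an expected range of 700 nM to 5000 nM.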

Compound 3, half-maximal inhibitory concentration: 2920 nM
Beside the measured number, compound 3's estimate is 1.6-fold (0.21 log units) below it; the range from low to high includes it.
By their numbers in this assay, from the lowest: compounds 2 and 1 (each within the scatter of the next); then compound 3.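

At this saturated chain carbon, this assay now shows a change beyond the scatter: 2-hydroxyethyl in place of isopropyl gives a 3.0-fold higher number from compound 2 to compound 3 (0.48 log units; beyond the scatter) on this exchange, and 2-hydroxyethyl in place of methylsulfanyl gives a 2.2-fold higher number from compound 1 to compound 3 (0.35 log units; beyond the scatter) on the other. The earlier pair could not be separated, so it left open whether this place responds to the group on it; the two new steps show that it does, modestly, with the group carrying a hydrogen-bond donor and a hydrogen-bond acceptor giving the higher number against both neighbours, although this rests on compound 3 alone. Nothing measured here accounts for the shift.

The compounds shown do not tell whether the higher number goes with the oxygen of 2-hydroxyethyl or with the chain as such, and a plain propyl chain or a 2-methoxyethyl group on the same carbon would bear on that. Going by these compounds, how an aminoethyl group or a carboxylic acid at this place would read in this assay also stays open, as does whether any group here can give a number clearly lower than those of compound 1 and compound 2.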